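This account rests on a few compounds, and the source may have more. Where it says the series, first, only, none or still open, it means among the compounds named here.

Measured so far in a functional assay on A549 cells (Homo sapiens) for inhibition, read by sulforhodamine B assay, with a stated time of 48 h; on this read-out higher numbers stand for weaker inhibition of growth and lower numbers for stronger inhibition of growth:

- compound 1 `Nc1cc(N)c2nc(-c3ccccc3)c(Oc3ccc(Cl)c(Cl)c3)nc2c1` gives 43700 nM
- compound 2 `Nc1cc(N)c2nc(-c3ccccc3)c(NCc3ccc(F)cc3)nc2c1` gives 34700 nM
- compound 3 `Nc1cc(N)c2nc(-c3ccccc3)c(Sc3ccc(Cl)c(Cl)c3)nc2c1` gives 52500 nM

All three share the same core and differ only in the group attached on one side of it. Compound 3 cannot be set apart from the others: the step of a 1.2-fold higher number from compound 1 to compound 3 (0.08 log units; within the scatter) and the step of a 1.5-fold higher number from compound 2 to compound 3 (0.18 log units; within the scatter) both fall inside the usual scatter, as does a 1.3-fold lower number from compound 1 to compound 2 (0.10 log units; within the scatter).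

Compound 4 `Nc1cc(N)c2nc(-c3ccccc3)c(Sc3ccc(F)cc3)nc2c1` keeps the sulfur link of compound 3 and changes the ring on it: 4-fluorophenyl in place of 3,4-dichlorophenyl on a sulfur. For the measured compounds named here, no measured step repeats this swap exactly. The closest guides are the steps from compound 1 to compound 2 and from compound 2 to compound 3, where a dichloro-substituted ring and a fluoro-substituted ring were exchanged together with the linker, and neither moved the number beyond the scatter. On that basis the expected step of a 1.2-fold lower number from compound 3 to compound 4 (0.07 log units; within the scatter) is none beyond the scatter, with no clear direction. Compound 4 is estimated at 45000 nM, within a range of 18000 nM to 110000 nM.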

Compound 4, concentration for total growth inhibition: 30900 nM
The estimate for compound 4 lay 1.5-fold (0.16 log units) above the measured number; the range from low to high includes it.
By their numbers in this assay, from the lowest: compounds 4, 2, 1 and 3 (each within the scatter of the next).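

Keeping the sulfur link fixed isolates the ring on it for the first time in this assay: 4-fluorophenyl in place of 3,4-dichlorophenyl gives a 1.7-fold lower number from compound 3 to compound 4 (0.23 log units; within the scatter). The two steps that also change the linker, a 1.1-fold lower number from compound 2 to compound 4 (0.05 log units; within the scatter) and a 1.4-fold lower number from compound 1 to compound 4 (0.15 log units; within the scatter), stay inside the scatter too, so none of the four compounds can be told apart at this position. No measurement at hand explains why these exchanges leave the number within the scatter.

Every group shown ends in a halogen-bearing aromatic ring, so it remains open whether a simple amine or a carboxylic acid in that place would move the number beyond the scatter. Also open, going by these compounds, is whether a plain phenyl on the sulfur, with no halogen, would read any differently.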